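This account rests on a few compounds, and the source may have more. Where it says the series, first, only, none or still open, it means among the compounds named here.

In a functional assay on HeLa cells (Homo sapiens) for antiproliferative activity, read by MTT assay, with a stated time of 48 h (a higher number here means a weaker inhibitor, a lower number a stronger inhibitor), compound 1 `COc1ccc(C(=O)c2ccc3c(c2)C=CC(C)(C)O3)c(NC(=O)CBr)c1` gives 3050 nM. That is level, within the scatter, with compound 3 `CCNCC(=O)Nc1cc(OC)ccc1C(=O)c1ccc(OC)c2c1C=CC(C)(C)O2` at 4270 nM, while compound 2 `COc1ccc(C(=O)c2ccc(OC)c3c2C=CC(C)(C)O3)c(NC(=O)CN)c1` shows a far lower number at 100 nM. Compound 4 `COc1ccc(C(=O)c2ccc3c(c2)C=CC(C)(C)O3)c(NC(=O)CN(C)C)c1` has dimethylamino in place of bromo on a saturated chain carbon bound to a carbonyl carbon. Among the measured compounds shown here, the one measured step on an amine nitrogen is a 43-fold higher number from compound 2 to compound 3 (1.63 log units; beyond the scatter), from ethyl replacing hydrogen, which is large and beyond the scatter. For the measured compounds named here, it comes from a different core, and no measured pair replaces bromo with an amine, so it is only a loose guide. Its nitrogen carries no hydrogen, so the expected result is a 1.0-fold lower number from compound 1 to compound 4 (0.01 log units; within the scatter), with no shift beyond the scatter. For compound 4 the estimate is 3000 nM, with an expected range of 700 nM to 12000 nM.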

Compound 4, half-maximal inhibitory concentration: 1260 nM
Beside the measured number, compound 4's estimate is 2.4-fold (0.38 log units) above it; the range from low to high includes it.
By their numbers in this assay, from the lowest: compound 2; then compound 4; then compounds 1 and 3 (each within the scatter of the next).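

On a saturated chain carbon bound to a carbonyl carbon, dimethylamino in place of bromo gives a 2.4-fold lower number from compound 1 to compound 4 (0.38 log units; beyond the scatter) in this assay, a modest step but beyond the scatter. Among the compounds shown here, it is the only measured pair here that changes the group at this place, and it shows that bromo is not needed to keep activity on the core of compound 1. No measurement shown accounts for the step.

Still open, as far as these compounds go, is how diethylamino or a carboxylic acid would read in this same place on this core.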